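The source may hold more compounds than are shown below. What is called first, only, known or untested is meant among the compounds shown, and "the series" means these compounds.

Series notes. Compound 1 `COc1ccc(/C=C/C(=O)OC[C@@H](OCc2ccccc2)[C@H]2OC(=O)C=C[C@H]2OCc2ccccc2)cc1` and compound 2 `O=C1C=C[C@@H](OCc2ccccc2)[C@@H]([C@@H](COC(=O)/C=C/c2ccc(F)cc2)OCc2ccccc2)O1` share one core; compound 3 `COc1ccc(/C=C/C(=O)OC[C@@H](OC(C)=O)[C@H]2OC(=O)C=C[C@H]2OC(C)=O)cc1` and compound 4 `CC(=O)O[C@@H]1C=CC(=O)O[C@@H]1[C@@H](COC(=O)/C=C/c1ccc(F)cc1)OC(C)=O` share another. The difference between the two cores is not broken down here. In a functional assay on MCF7 cells (Homo sapiens) for antiproliferative activity, read by MTT assay, with a stated time of 6 days (on this read-out lower numbers stand for stronger inhibition and higher numbers for weaker inhibition), compound 1 gives 1110 nM. The change fluoro in place of methoxy on an aromatic carbon gives a 2.7-fold higher number from compound 1 to compound 2 (0.43 log units; beyond the scatter), and compound 2 gives 3010 nM in this assay. Compound 3 gives 9310 nM in this assay, the highest number of the three measured compounds. Compound 4 is not yet measured. The change fluoro in place of methoxy on an aromatic carbon is the same change as that from compound 1 to compound 2, made on the other core, and the place is described in the same words for both pairs. For the measured compounds named here, a step of similar size is expected for compound 4, because a 2.7-fold higher number from compound 1 to compound 2 (0.43 log units; beyond the scatter) is the only precedent for this change, although a single pair cannot show whether the step carries over to the second core. The expected step is a 2.5-fold higher number from compound 3 to compound 4 (0.39 log units; beyond the scatter). The estimate for compound 4 in this assay is 23000 nM, with a range from 9000 nM to 60000 nM.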

Compound 4, half-maximal inhibitory concentration: 4260 nM
The estimate for compound 4 lay 5.4-fold (0.73 log units) above the measured number, outside the stated range (below it).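

On the second core, fluoro in place of methoxy on an aromatic carbon gives a 2.2-fold lower number from compound 3 to compound 4 (0.34 log units; beyond the scatter) in this assay, a step in the opposite direction to the one on the core of compound 1. The two steps differ, so in this series the change does not carry over from one core to the other: the same change on two cores in this assay, a 2.7-fold higher number (0.43 log units; beyond the scatter) from compound 1 to compound 2 and a 2.2-fold lower number (0.34 log units; beyond the scatter) from compound 3 to compound 4, 5.9-fold (0.77 log units) apart, beyond the scatter of two such steps. This shows that a step read on one of these cores does not give even the direction of the step on the other, but it does not show which part of the difference between the cores matters, and two pairs say nothing about any further core.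

Still open, going by these compounds, is whether chloro or trifluoromethyl, on the same aromatic carbon para to a large group, would split the two cores in the same way. Also open, on these data alone, is how the step would run on a core carrying free hydroxyl groups in place of the groups that separate these two cores.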